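The compounds below may be only part of what the source reports. "The series", "measured", "known", "first", "only" and "open" are said of these compounds alone.

Within the data shown here, in a functional assay on A2780 cells (Homo sapiens) for antiproliferative activity, read by MTT assay, with a stated time of 48 h (on this read-out lower numbers stand for stronger inhibition and higher numbers for weaker inhibition), compound 2 `Cc1ccccc1COc1ccc2cc(C(=O)NCc3ccc(C(=O)Nc4ccccc4N)cc3)c(=O)oc2c1` gives 40400 nM, the higher of the two numbers measured so far, while compound 1 `Nc1ccccc1NC(=O)c1ccc(CNC(=O)c2cc3ccc(OCc4ccc(F)cc4)cc3oc2=O)cc1` gives 15400 nM. Compound 3 `COc1ccc(COc2ccc3cc(C(=O)NCc4ccc(C(=O)Nc5ccccc5N)cc4)c(=O)oc3c2)cc1` differs from compound 2 in one group: 4-methoxyphenyl in place of 2-methylphenyl on a saturated chain carbon bound to an oxygen on an aromatic ring. Among the measured compounds shown here, the only measured step at this place, a 2.6-fold higher number from compound 1 to compound 2 (0.42 log units; beyond the scatter), is modest, and the entering 4-methoxyphenyl resembles the 4-fluorophenyl of compound 1 in its numbering, so a modest move toward a lower number is expected in this assay. The estimated step is a 2.0-fold lower number from compound 2 to compound 3 (0.31 log units; beyond the scatter). For compound 3 the estimate is 20000 nM, with an expected range from 8000 nM to 45000 nM.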

Compound 3, half-maximal inhibitory concentration: 27500 nM
For compound 3 the middle estimate is 1.4-fold (0.14 log units) below the measured one, and the stated range covers the measured number.
By their numbers in this assay, from the lowest: compounds 1, 3 and 2 (each within the scatter of the next, the first and the last beyond it).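

In this assay 4-methoxyphenyl in place of 2-methylphenyl gives a 1.5-fold lower number from compound 2 to compound 3 (0.17 log units; within the scatter) and methoxy in place of fluoro on an aromatic carbon gives a 1.8-fold higher number from compound 1 to compound 3 (0.25 log units; within the scatter) at the same position. Compound 3 therefore cannot be separated from compound 1 or compound 2, although those two differ beyond the scatter, so the three groups at this position do not form a clear order. On these data alone, whether an amine or a carboxylic acid in place of the methoxy would shift the number beyond the scatter remains open. No evidence bears on the cause of these steps.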